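A few compounds are considered here, and "the series" means these few. Any claim that something is new, unique, unknown or untested is made for them only; others in the source may bear on it.

Measured in a functional assay (muscle tissue) with Cavia porcellus as the target; a higher number here means that more compound is needed for the effect, a lower number that less compound is needed:
compound 1 `COC(=O)C1=C(C)N=C(C)/C(=C(\O)OC)C1c1cc(Cl)cc(Cl)c1`: 93.3 nM
compound 2 `COC(=O)C1=C(C)N=C(C)/C(=C(\O)OC)C1c1cccc(Br)c1`: 1.29 nM
compound 3 `COC(=O)C1=C(C)N=C(C)/C(=C(\O)OC)C1c1cccc(C)c1`: 110 nM

Compound 3 has the highest number of the three, but the gap to its nearest neighbour lies within the scatter: a 1.2-fold higher number from compound 1 to compound 3 (0.07 log units; within the scatter). The large gaps involve only the 3-bromophenyl compound: an 85-fold higher number from compound 2 to compound 3 (1.93 log units; beyond the scatter), and a 72-fold lower number from compound 1 to compound 2 (1.86 log units; beyond the scatter).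

The next change gives compound 4 `COC(=O)C1=C(C)N=C(C)/C(=C(\O)OC)C1c1ccc(Br)cc1`: 4-bromophenyl in place of 3-methylphenyl on a saturated ring carbon. Bromo returns, but as 4-bromophenyl, a group no measured compound carries. The low number of compound 2 (1.29 nM) therefore cannot simply be carried over, and no large drop is expected in this assay. A moderate rise is expected instead, with wide uncertainty. The expected change is a 2.7-fold higher number from compound 3 to compound 4 (0.44 log units; beyond the scatter). Compound 4 is estimated at 300 nM, with an expected range of 20 nM to 3000 nM.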

Compound 4, half-maximal effective concentration: 540 nM
Beside the measured number, compound 4's estimate is 1.8-fold (0.26 log units) below it; the range from low to high includes it.
By their numbers in this assay, from the lowest: compound 2; then compounds 1 and 3 (each within the scatter of the next); then compound 4.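

In this assay, the step from 3-bromophenyl to 4-bromophenyl gives a 420-fold higher number from compound 2 to compound 4 (2.62 log units; beyond the scatter), the largest step among these compounds, so the low number of compound 2 does not follow from bromo alone. The other two steps are smaller: a 4.9-fold higher number from compound 3 to compound 4 (0.69 log units; beyond the scatter) and a 5.8-fold higher number from compound 1 to compound 4 (0.76 log units; beyond the scatter). Compound 4 therefore has the highest number of the four, and the aryl substitution pattern at this saturated ring carbon matters.

Nothing available accounts for the gap between the two bromophenyl groups. From the compounds shown here alone, whether a phenyl ring bearing an amine or a methoxy group could match compound 2 remains open.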